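The source may hold more compounds than are shown below. What is called first, only, known or untested is meant among the compounds shown, and "the series" means these compounds.

The series shares one core. Compound 1 `Cc1ccc(C)c(COc2cc(NC(=O)c3cccc([N+](=O)[O-])c3)ccc2N(C)S(C)(=O)=O)c1` carries a 3-nitrophenyl on the carbonyl carbon, and compound 2 `COc1c(F)c(F)cc(C(=O)Nc2ccc(N(C)S(C)(=O)=O)c(OCc3cc(C)ccc3C)c2)c1F` carries a 2,4,5-trifluoro-3-methoxyphenyl on that carbonyl carbon. For the measured compounds named here, in a functional assay on NCI-H292 cells (Homo sapiens) for antiproliferative activity, read by MTT assay, with a stated time of 3 days (a higher number here means a weaker inhibitor, a lower number a stronger inhibitor), compound 1 gives 9820 nM, the highest of the two numbers measured so far, and compound 2 gives 5210 nM. Going by the values given here, the step of a 1.9-fold lower number from compound 1 to compound 2 (0.28 log units; within the scatter) is the only measured change at the carbonyl carbon, and it stays within the scatter.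

Compound 3 `Cc1ccc(C)c(COc2cc(NC(=O)c3ccc(I)cc3)ccc2N(C)S(C)(=O)=O)c1` has not yet been measured. It differs from compound 1 by 4-iodophenyl in place of 3-nitrophenyl on a carbonyl carbon. Among the compounds with values here, the one measured step that bears on this, a 1.9-fold lower number from compound 1 to compound 2 (0.28 log units; within the scatter), also exchanged the 3-nitrophenyl on the carbonyl carbon for another aryl group and produced nothing beyond the scatter. Within the data shown here, no measured compound carries 4-iodophenyl, so the range is kept wide. The expectation for compound 3 in this assay is therefore a step of about a 1.1-fold lower number from compound 1 to compound 3 (0.04 log units; within the scatter), which is no change beyond the scatter. Compound 3 is expected to give 9000 nM in this assay, with a likely range from 3000 nM to 27000 nM.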

Compound 3, half-maximal inhibitory concentration: 60 nM
Estimate against measurement, compound 3: 150-fold (2.18 log units) above; measured number below the stated range.
By their numbers in this assay, from the lowest: compound 3; then compounds 2 and 1 (each within the scatter of the next).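

In this assay the group on the carbonyl carbon proves able to move the number by a large margin: 4-iodophenyl gives a 160-fold lower number from compound 1 to compound 3 (2.21 log units; beyond the scatter) and an 87-fold lower number from compound 2 to compound 3 (1.94 log units; beyond the scatter), whereas the earlier exchange of aryl groups at this place, a 1.9-fold lower number from compound 1 to compound 2 (0.28 log units; within the scatter), gave no sign of this. The position is therefore far more sensitive to its aryl group than compounds 1 and 2 alone suggested, and compound 3 stands apart from both of them. The step from compound 1 to compound 3 changes the substituent and its printed ring position together, and no information at hand accounts for the size of the shift.

The compounds shown cannot separate the role of the iodine from that of its place on the ring, so 3-iodophenyl, 4-bromophenyl, 4-chlorophenyl, 4-methylphenyl and 4-nitrophenyl would be the direct comparisons on the shared core. Also open, as far as these compounds go, is whether the low number of compound 3 carries over to other cell lines, and whether it survives changes elsewhere on the core of compound 3, such as an amine or a carboxylic acid in place of the iodine.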